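A few compounds are considered here, and "the series" means these few. Any claim that something is new, unique, unknown or untested is made for them only; others in the source may bear on it.

Measured compounds:
compound 1, `N#C/C(=C\N1CCN(C(=O)c2ccco2)C1=S)C(N)=O`; in a functional assay on SF-295 cells (Homo sapiens) for inhibition, read by sulforhodamine B assay, with a stated time of 48 h (a lower number here means a stronger inhibitor of growth, a higher number a weaker inhibitor of growth), compound 1 gives 32100 nM
compound 2, `O=CN1CCN(C(=O)c2ccco2)C1=S`; compound 2 gives 21400 nM
compound 3, `O=CN1CCN(c2ccc(Cl)c(Cl)c2)C1=S`; compound 3 gives 18000 nM

Compound 1 carries the highest number of the three, but its gaps to compound 2 and to compound 3 both lie within the usual scatter, so no order among the three is established in this assay. For the measured compounds named here, no pair of measured compounds differing in a single place is available in this set, so there is no measured step to lean on.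

Compound 4, `N#C/C(=C\N1CCN(C(=O)c2ccco2)C1=S)C(=O)c1ccccc1`, has not yet been measured in this assay. It differs from compound 1 in one place: phenyl in place of amino on a carbonyl carbon. Going by the values given here, none of the measured compounds reports on this change, so it has no precedent here. The estimated step, a 1.6-fold lower number from compound 1 to compound 4 (0.21 log units; within the scatter), is modest, with the direction uncertain and not clearly beyond the scatter. Compound 4 is accordingly expected to give 20000 nM in this assay, with a likely range from 6000 nM to 60000 nM.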

Compound 4, concentration for 50% growth inhibition: 43600 nM
For compound 4 the middle estimate is 2.2-fold (0.34 log units) below the measured one, within the range that was stated.
By their numbers in this assay, from the lowest: compounds 3, 2, 1 and 4 (each within the scatter of the next, the first and the last beyond it).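

In this assay, for the compounds shown here, the first comparison in this set that differs in a single place, phenyl in place of amino on a carbonyl carbon gives a 1.4-fold higher number from compound 1 to compound 4 (0.13 log units; within the scatter). This position therefore accepts the change from carbamoyl to benzoyl, with six heavy atoms entering for one and a hydrogen-bond donor leaving, without a resolved shift in the read-out, and compound 4 at 43600 nM stays in the same range as compound 1 at 32100 nM. Nothing available bears on why this change leaves the number within the scatter.

Still open, from the compounds shown here alone, is whether any group on this carbonyl carbon can move the number beyond the scatter. A carboxylic acid, a dimethylamino group or a longer alkyl chain at this place would test that.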